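Cytotoxicity notes: dimethylamino entry on the phenoxy ring

This account rests on a few compounds, and the source may have more. Where it says the series, first, only, none or still open, it means among the compounds named here.

Three compounds of this series have a number in an ADME assay on HepG2 cells (Homo sapiens) for cytotoxicity, read by luminescence, CellTiter-Glo and ATP content, with a stated time of 72 h; on this read-out lower numbers stand for an effect already at smaller amounts and higher numbers for an effect only at larger amounts of compound. Compound 1 `COc1cccc(CNCCCNc2ccnc3cc(Oc4ccccc4)ccc23)c1O` gives 6800 nM. Compound 2 `COc1ccc(F)cc1CNCCCNc1ccnc2cc(Cc3ccc(F)cc3Cl)ccc12` gives 2460 nM, and compound 3 `c1ccc(Oc2ccc3c(NCCCNCc4ccco4)ccnc3c2)cc1` gives 15200 nM. On these numbers compound 1 stands second highest of three; the nearest is compound 3, with a 2.2-fold higher number from compound 1 to compound 3 (0.35 log units; beyond the scatter), the furthest is compound 2, whose lower number comes with several structural differences at once, so no single step can be read from it.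

Compound 4 `COc1cccc(CNCCCNc2ccnc3cc(Oc4cccc(N(C)C)c4)ccc23)c1O` has not yet been measured in this assay. It differs from compound 1 by dimethylamino in place of hydrogen on an aromatic carbon, the same difference read one bond further out being phenoxy to 3-(dimethylamino)phenoxy. Going by the values given here, the only measured single step, from compound 1 to compound 3, concerns the other end of the molecule, the group on the saturated chain carbon bound to an amine nitrogen, and says nothing about a change on the phenoxy ring. Among the compounds with values here, no measured step therefore bears on this change, and the expectation is no step beyond the scatter in this assay, in either direction. Compound 4 is accordingly estimated at 6800 nM, with a range from 3000 nM to 15000 nM, which is expected to mean no change at the digits printed from compound 1 to compound 4 (within the scatter).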

Compound 4, half-maximal effective concentration: 7300 nM
Beside the measured number, compound 4's estimate is 1.1-fold (0.03 log units) below it; measured number inside the range.
By their numbers in this assay, from the lowest: compound 2; then compounds 1 and 4 (each within the scatter of the next); then compound 3.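

The phenoxy ring now has its first measured change: in this assay, dimethylamino in place of hydrogen on an aromatic carbon gives a 1.1-fold higher number from compound 1 to compound 4 (0.03 log units; within the scatter) and so does not separate the two compounds. Going by these compounds alone, at this position, then, the phenoxy to 3-(dimethylamino)phenoxy change adds 3 heavy atoms with no step beyond the scatter, whereas the only earlier single step, at the other end of the molecule, gives a 2.2-fold higher number from compound 1 to compound 3 (0.35 log units; beyond the scatter) and lies beyond it. No measured evidence at hand accounts for this result.

Going by these compounds, whether a carboxylic acid or a primary amine on the same aromatic carbon would read the same remains open. Also open, on these data alone, is whether dimethylamino on the phenoxy ring would give a similar reading with the furan-2-yl group of compound 3 at the other end.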